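This account rests on a few compounds, and the source may have more. Where it says the series, first, only, none or still open, it means among the compounds named here.

Measured in a functional assay on NCI-H522 cells (Homo sapiens) for cytotoxicity, with a stated time of 3 days; on this read-out higher numbers stand for weaker inhibition and lower numbers for stronger inhibition:
compound 1 `C#Cc1nccs1` gives > 40000 nM as a limit
compound 2 `CC#Cc1nc(C(=O)OCC)cs1` gives > 40000 nM as a limit
compound 3 `C=Cc1nc(C(=O)OCC)cs1` gives > 40000 nM as a limit

For the measured compounds named here, all three entries are limits, not numbers, and the series so far shows the limit of > 40000 nM in this assay, at which 3 of the 3 values shown sit, and nothing else. Compound 1 stands at > 40000 nM as a limit, so no number places it. The change to compound 4 `N#Cc1nccs1` is cyano in place of ethynyl on an aromatic carbon. Going by the values given here, the only measured step (a step that the two limits leave unreadable from compound 2 to compound 3) is a different exchange and lends no size. No step beyond the scatter is therefore expected in this assay and no direction is favoured. The expected step is a number no higher from compound 1 to compound 4 (the limit leaves the size open) and a limit is the likeliest report. For compound 4 the estimate is 40000 nM (expected range 15000 nM to 80000 nM).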

Compound 4, half-maximal inhibitory concentration: > 40000 nM
Compound 4: no number, only a limit (the forecaster's own chance of this, stated with the estimate: 85%); the middle value lies on the limit itself.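

No step can be read between compound 1 and compound 4, as both are reported only as limits: the limit of > 40000 nM in this assay, at which 4 of the 4 values shown sit.

The compounds shown leave open which structural change, if any, would give a measured number in this assay.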